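The source may hold more compounds than are shown below. What is called first, only, known or untested is meant among the compounds shown, and "the series" means these compounds.

Compound 1 `O=c1cc(-n2cc(-c3ccccc3)nn2)c2cc(Br)ccc2o1`: 11200 nM
Compound 2 `O=c1cc(-n2cc(COc3ccccc3)nn2)c2cc(Br)ccc2o1`: 12300 nM
Compound 3 `COC(=O)c1ccccc1OCc1cn(-c2cc(=O)oc3ccc(Br)cc23)nn1`: 5250 nM

In a functional assay on A549 cells (Homo sapiens) for antiproliferative activity, read by MTT assay, with a stated time of 48 h (a higher number here means a weaker inhibitor, a lower number a stronger inhibitor), compound 2 gives the highest of the three numbers. Compound 1 lies within the scatter of it, as a 1.1-fold higher number from compound 1 to compound 2 (0.04 log units; within the scatter) shows, whereas compound 3 stands beyond it, with a 2.3-fold lower number from compound 2 to compound 3 (0.37 log units; beyond the scatter). Compound 4 `COC(=O)c1ccc(OCc2cn(-c3cc(=O)oc4ccc(Br)cc34)nn2)cc1` differs from compound 2 by methoxycarbonyl in place of hydrogen on an aromatic carbon. Within the data shown here, the one measured step that bears on this change is the same exchange made on a different aromatic carbon of the same ring, from compound 2 to compound 3, which gave a 2.3-fold lower number from compound 2 to compound 3 (0.37 log units; beyond the scatter), a modest gain. A step of about that size, towards a lower number, is therefore expected here: a 2.1-fold lower number from compound 2 to compound 4 (0.31 log units; beyond the scatter). Compound 4 is estimated at 6000 nM in this assay, with a range from 2500 nM to 15000 nM.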

Compound 4, half-maximal inhibitory concentration: 660 nM
Compound 4: the middle estimate sits 9.1-fold (0.96 log units) above what was measured; measured number below the stated range.
By their numbers in this assay, from the lowest: compound 4; then compound 3; then compounds 1 and 2 (each within the scatter of the next).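

In this assay, methoxycarbonyl para to a large group gives a 19-fold lower number from compound 2 to compound 4 (1.27 log units; beyond the scatter), so this carbon of the ring responds far more strongly to the exchange than the earlier step suggested. Compound 3, carrying the same group on a different carbon of that ring, gives 5250 nM, whereas compound 4 gives 660 nM, so the place of the group on this ring matters here. Nothing measured here accounts for this gain.

Whether the methoxycarbonyl itself is needed remains open, since the compounds shown include no carboxylic acid, amide or nitrile at this carbon. Going by these compounds, whether the gain carries over to a core without the bromine is also open.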